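The source may report more compounds than this note shows. Statements on the series, on what has been measured and on what is new or still open speak of the compounds shown alone.

Compound 2 `Cn1ccc2c(Oc3ccc(NC(=O)c4cn(-c5ccc(Cl)cc5)c5ccccc5c4=O)cc3F)ccnc21` gives 250 nM.
Compound 1 `O=C(Nc1ccc(Oc2ccnc3[nH]ccc23)cc1)c1cn(-c2ccc(Cl)cc2)c2ccccc2c1=O` gives 650 nM.
Compound 3 `Cn1ccc2c(Oc3ccc(NC(=O)c4cn(-c5ccc(Br)cc5F)c5ccccc5c4=O)cc3F)ccnc21` gives 1520 nM.

These numbers come from a functional assay on A549 cells (Homo sapiens) for inhibition, read by MTT assay, with a stated time of 72 h; a higher number here means a weaker inhibitor, a lower number a stronger inhibitor. Among the three, compound 2 has the lowest number; compound 1 sits a little higher, beyond the scatter, and compound 3 is the furthest away, so compound 2 is the strongest inhibitor of the three.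

Compound 4 `O=C(Nc1ccc(Oc2ccnc3[nH]ccc23)c(F)c1)c1cn(-c2ccc(Cl)cc2)c2ccccc2c1=O` is compound 2 with one change: hydrogen in place of methyl on an aromatic nitrogen. Among the compounds with values here, the only step measured in one place, a 6.1-fold higher number from compound 2 to compound 3 (0.78 log units; beyond the scatter), concerns the group on the other aromatic nitrogen, not the one changed here, so it says little about this step. Compound 1 also lacks the methyl, but it lacks the fluorine as well, so two things change between compound 1 and compound 2; all that can be read from those two is that compound 1 gives the higher number of the pair. That is a weak hint that removing the methyl costs some potency.

On that basis a modest rise in the number is expected, a 2.0-fold higher number from compound 2 to compound 4 (0.30 log units; within the scatter). Compound 4 is therefore estimated at 500 nM in this assay, with a range from 200 nM to 1500 nM.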

Compound 4, half-maximal inhibitory concentration: 320 nM
Beside the measured number, compound 4's estimate is 1.6-fold (0.19 log units) above it; measured number inside the range.
By their numbers in this assay, from the lowest: compounds 2 and 4 (each within the scatter of the next); then compound 1; then compound 3.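

Replacing the methyl on the aromatic nitrogen with hydrogen gives a 1.3-fold higher number from compound 2 to compound 4 (0.11 log units; within the scatter) in this assay, so at this position the methyl and the hydrogen cannot be told apart, and the weak hint from the earlier pair that the methyl matters finds no support. Compound 4 also separates the two changes that were mixed between compound 1 and compound 2: with the nitrogen hydrogen held constant, fluoro in place of hydrogen on an aromatic carbon gives a 2.0-fold lower number from compound 1 to compound 4 (0.31 log units; beyond the scatter), a modest step but one beyond the scatter, so this single change, not the methyl, is the one that registers in these compounds. No measurement here explains why either step has the size it does.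

Only hydrogen and methyl are shown on this nitrogen, so it remains open whether an ethyl group, or a longer chain ending in an amine, would leave the number unchanged. Only fluoro and hydrogen are shown on the aromatic carbon, so a chloro or methoxy group there is an open question, as is whether the fluoro step would be the same size with the methyl present.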